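This account rests on a few compounds, and the source may have more. Where it says the series, first, only, none or still open, it means among the compounds named here.

Working notes on the series. Compound 1 `O=C(NCCO)Nc1nc2cc(C(=O)c3ccccc3)ccc2[nH]1` and compound 2 `CN1CCC(Cn2c(N)nc3ccc(C(=O)c4ccccc4)cc32)CC1` share a core and were both run in an ADME assay on HL-60 cells (Homo sapiens) for cytotoxicity, read by resazurin assay, with a stated time of 72 h; on this read-out higher numbers stand for an effect only at larger amounts of compound and lower numbers for an effect already at smaller amounts. In this assay compound 1 returns only a limit, > 30000 nM. Compound 2 likewise returns only a limit in this assay, > 30000 nM. Among the measured compounds shown here, compound 2 therefore stands at the limit of > 30000 nM in this assay, at which 2 of the 2 values shown sit, and no step between measured compounds can be read from these two values. Compound 3 `Nc1nc2ccc(C(=O)c3ccccc3)cc2n1C[C@@H]1CCCN1` is the next member to be measured; it differs from compound 2 as follows: pyrrolidin-2-yl in place of 1-methylpiperidin-4-yl on a saturated chain carbon bound to an aromatic nitrogen. With both known values sitting at the limit, no direction can be taken from the measured pair; the step expected in this assay from compound 2 to compound 3 is a step that the limit leaves unreadable from compound 2 to compound 3, that is, none beyond the scatter. For compound 3 the estimated value in this assay is 40000 nM, within a range from 15000 nM to 120000 nM, and it is expected that the assay again reports only a limit.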

Compound 3, half-maximal effective concentration: > 30000 nM
Compound 3 gave a limit, no number (the forecaster's own chance of this, stated with the estimate: 70%); the middle value does not contradict the limit.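

Among the compounds shown here, no step from compound 2 to compound 3 can be read in this assay, as compound 3 also returns only a limit: the limit of > 30000 nM in this assay, at which 3 of the 3 values shown sit. The compounds shown leave open whether any member with the shared core reaches a measurable half-maximal effective concentration on these cells.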